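Amide substituent changes on a shared bisindolylmaleimide-type core

The source may hold more compounds than are shown below. What is called first, only, known or untested is meant among the compounds shown, and "the series" means these compounds.

Measured so far:
compound 1 `COC(=O)CCNC(=O)Cn1cc(C2=C(c3c[nH]c4ccccc34)C(=O)N(C)C2=O)c2ccccc21` — 44500 nM
compound 2 `COC(=O)[C@H](NC(=O)Cn1cc(C2=C(c3c[nH]c4ccccc34)C(=O)N(C)C2=O)c2ccccc21)C(C)C` — 23800 nM

In a functional assay on A2780 cells (Homo sapiens) for cytotoxicity, read by MTT assay, with a stated time of 24 h (a lower number here means a stronger inhibitor, a higher number a weaker inhibitor), compound 1 gives 44500 nM, the highest of the two numbers available. Compound 2, which carries 1-(methoxycarbonyl)-2-methylpropyl in place of 2-(methoxycarbonyl)ethyl on the amide-type nitrogen, gives 23800 nM in this assay; the shift a 1.9-fold lower number from compound 1 to compound 2 (0.27 log units; within the scatter) does not leave the scatter, so the two compounds cannot be ordered.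

Compound 3 `COC(=O)CC[C@@H](NC(=O)Cn1cc(C2=C(c3c[nH]c4ccccc34)C(=O)N(C)C2=O)c2ccccc21)C(=O)OC` is the next variation at the same position. Relative to compound 1 the change is 1,3-bis(methoxycarbonyl)propyl in place of 2-(methoxycarbonyl)ethyl on an amide-type nitrogen. Among the measured compounds shown here, the only step that bears on it is the one from compound 1 to compound 2, a swap of the ester-bearing chain on the same nitrogen, and that step was a 1.9-fold lower number from compound 1 to compound 2 (0.27 log units; within the scatter), within the scatter. On that basis no step beyond the scatter is expected in this assay for compound 3 either, with at most a small drift towards lower numbers, giving an expected 1.3-fold lower number from compound 1 to compound 3 (0.10 log units; within the scatter). Compound 3 is therefore estimated at 35000 nM in this assay, with a range from 15000 nM to 80000 nM.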

Compound 3, half-maximal inhibitory concentration: 32300 nM
For compound 3 the middle estimate is 1.1-fold (0.03 log units) above the measured one; low and high end bracket the measured number.
By their numbers in this assay, from the lowest: compounds 2, 3 and 1 (each within the scatter of the next).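

In this assay there is a 1.4-fold lower number from compound 1 to compound 3 (0.14 log units; within the scatter) when 1,3-bis(methoxycarbonyl)propyl replaces 2-(methoxycarbonyl)ethyl on the amide-type nitrogen, so a second methoxycarbonyl group and a defined stereocentre on this chain do not separate compound 3 from compound 1. The comparison on the saturated chain carbon bound to an amide-type nitrogen and a carbonyl carbon, with 2-(methoxycarbonyl)ethyl in place of isopropyl, gives a 1.4-fold higher number from compound 2 to compound 3 (0.13 log units; within the scatter) and also stays inside the scatter, so an ester-bearing side chain and a branched hydrocarbon one cannot be told apart at that carbon, and the three compounds cannot be ordered. No measurement is available that would explain these numbers.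

On these data alone, all three substituents on this nitrogen end in methyl esters, so it remains open whether a free carboxylic acid, a primary amine or an amide in place of an ester would produce a step beyond the scatter. Also open, as far as these compounds go, are a longer chain between the nitrogen and the ester and the opposite configuration at the stereocentre of compound 2 or compound 3.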